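This account rests on a few compounds, and the source may have more. Where it says the series, first, only, none or still open, it means among the compounds named here.

Measured so far:
- compound 1 `COc1cc(/C=C/C(=O)/C=C(/C=C/c2ccc(OC(C)=O)c(OC)c2)NC2CCCCC2)ccc1OC(C)=O`: 113%
- compound 2 `CCCNC(=C\C(=O)/C=C/c1ccc(O)c(OC)c1)/C=C/c1ccc(O)c(OC)c1`: 141%
- compound 3 `C=CCNC(=C\C(=O)/C=C/c1ccc(O)c(OC)c1)/C=C/c1ccc(O)c(OC)c1`: 267%

In a functional assay on EA.hy 926 cells (Homo sapiens), read by fluorescence, tested at 10 uM (on this read-out lower numbers stand for a weaker effect and higher numbers for a stronger effect at the one concentration tested), compound 1 stands lowest of the three numbers. The nearest is compound 2, whose value sits higher than that of compound 1 by a margin beyond the scatter; the furthest is compound 3, well above both. Going by the values given here, the single measured step, a number 126 percentage points higher from compound 2 to compound 3 (beyond the scatter), is large, but it concerns a different change on the amine nitrogen, and both of its compounds carry free phenols where compound 1 carries acetates; it gives no direct guide for the change considered here.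

Compound 4 `COc1cc(/C=C/C(=O)/C=C(/C=C/c2ccc(OC(C)=O)c(OC)c2)NCC(C)C)ccc1OC(C)=O` differs from compound 1 by isobutyl in place of cyclohexyl on an amine nitrogen. Among the compounds with values here, no measured pair shows this exchange or a near relative of it, so the only anchor is the value of compound 1 itself. Within the data shown here, without a bearing step, the expectation is no change beyond the scatter, that is a step of a number 7 percentage points higher from compound 1 to compound 4 (within the scatter) on the activity read-out, with a wide margin of uncertainty given how strongly the one measured change at this nitrogen moved the number. The estimate for compound 4 in this assay is therefore 120%, expected to fall between 80% and 190%.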

Compound 4, a percentage reported as activity, at one concentration (the size of the read-out at that concentration, not a potency): 240%
For compound 4 the middle estimate is 120 percentage points below the measured one; the whole stated range lies below it.
By their numbers in this assay, from the lowest: compound 1; then compound 2; then compound 4; then compound 3.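

In this assay, going by these compounds alone, the core of compound 1, with its acetates, proves sensitive to the group on the amine nitrogen: isobutyl in place of cyclohexyl gives a number 127 percentage points higher from compound 1 to compound 4 (beyond the scatter), a large step that the earlier compounds could not show for this exchange. Alongside a number 126 percentage points higher from compound 2 to compound 3 (beyond the scatter), seen with free phenols, the series now has two large steps from single changes at this nitrogen, although the two changes differ and neither pair tests the exchange made in the other. Nothing available accounts for the size of the new step or says which difference between cyclohexyl and isobutyl drives it.

Still open, from the compounds shown here alone, is whether the higher number follows from losing the ring, from the branched chain or from the smaller group, and a straight butyl chain, a cyclopentyl ring or a benzyl group on the same nitrogen would help separate these. Also open, going by these compounds, is whether the exchange gives a step of similar size on the free-phenol core, and how an allyl group behaves on the core with acetates.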